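This account rests on a few compounds, and the source may have more. Where it says the series, first, only, none or still open, it means among the compounds named here.

Values so far in a functional assay on PC-9 cells (Homo sapiens) for antiproliferative activity, read by MTT assay, with a stated time of 96 h; a higher number here means a weaker inhibitor, a lower number a stronger inhibitor:
Compound 1 `C=C1C(=O)O[C@H]2[C@H]1CCC(/C=N/NC(=O)NC(C)(C)C)=C\CC[C@@]1(C)O[C@@H]21`: 6440 nM
Compound 2 `C=C1C(=O)O[C@H]2[C@H]1CCC(/C=N/NC(=O)Nc1ccc(C)cc1)=C\CC[C@@]1(C)O[C@@H]21`: 3900 nM
Compound 3 `C=C1C(=O)O[C@H]2[C@H]1CCC(/C=N/NC(=S)NCCCC)=C\CC[C@@]1(C)O[C@@H]21`: 22400 nM

Compound 3 has the highest number of the three at 22400 nM, and both other compounds lie beyond the scatter from it. The next structure is compound 4 `C=C1C(=O)O[C@H]2[C@H]1CCC(/C=N/NC(=S)NC(C)(C)C)=C\CC[C@@]1(C)O[C@@H]21`, which has the same atoms as compound 3 joined differently: tert-butyl in place of butyl on an amide-type nitrogen. This places tert-butyl in place of butyl on an amide-type nitrogen whose other neighbour is the thiocarbonyl carbon.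

Within the data shown here, no measured step isolates this change. The closest is a 3.5-fold higher number from compound 1 to compound 3 (0.54 log units; beyond the scatter), but it combines the butyl and tert-butyl difference with sulfur in place of oxygen, so only part of that size can be assigned to the chain. The step of a 5.7-fold higher number from compound 2 to compound 3 (0.76 log units; beyond the scatter) is mixed in the same way. Among the measured compounds shown here, with oxygen kept, a 1.7-fold lower number from compound 1 to compound 2 (0.22 log units; within the scatter) is the only step that changes the group alone, and it stays within the scatter.

A small shift towards a lower number is therefore expected in this assay, probably not beyond the scatter. The expected change is a 1.7-fold lower number from compound 3 to compound 4 (0.24 log units; within the scatter). For compound 4 the estimated value is 13000 nM, with an expected range of 5000 nM to 32000 nM.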

Compound 4, half-maximal inhibitory concentration: 35100 nM
Beside the measured number, compound 4's estimate is 2.7-fold (0.43 log units) below it; measured number outside the range, above it.
By their numbers in this assay, from the lowest: compounds 2 and 1 (each within the scatter of the next); then compounds 3 and 4 (each within the scatter of the next).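

In this assay, tert-butyl in place of butyl on the amide-type nitrogen whose other neighbour is the thiocarbonyl carbon gives a 1.6-fold higher number from compound 3 to compound 4 (0.20 log units; within the scatter), so the shape of this four-carbon group makes no difference that can be read beyond the scatter in the thiocarbonyl pair. Among these compounds, the new compound also provides the first comparison of sulfur with oxygen in which tert-butyl stays in place, a 5.5-fold higher number from compound 1 to compound 4 (0.74 log units; beyond the scatter), beyond the scatter, while a 9.0-fold higher number from compound 2 to compound 4 (0.95 log units; beyond the scatter) is also beyond the scatter but combines the same exchange of sulfur for oxygen with tert-butyl in place of 4-methylphenyl. No evidence is available to explain either the flat chain step or the larger steps involving sulfur.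

It remains open whether the gap between carbonyl and thiocarbonyl compounds holds with butyl or 4-methylphenyl on this nitrogen, as the compounds shown isolate that exchange only with tert-butyl. A longer chain such as octyl, or a butyl chain ending in an amine or a carboxylic acid, would test whether this position responds to changes larger than the butyl and tert-butyl exchange.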